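The source may hold more compounds than are shown below. What is called first, only, known or untested is meant among the compounds shown, and "the series" means these compounds.

Compound 1 `CCCS(=O)(=O)Nc1ccc(F)c(C(=O)c2n[nH]c3ncc(-c4ccccc4O)cc23)c1F`: 9%
Compound 2 `CCCS(=O)(=O)Nc1ccc(F)c(C(=O)c2n[nH]c3ncc(-c4ccc(S(C)(=O)=O)cc4)cc23)c1F`: 1.5%

Both were measured in an assay for binding affinity to dual specificity mitogen-activated protein kinase kinase 4 (Homo sapiens), read by KINOMEscan, tested at 100 nM; on this read-out lower numbers stand for a stronger effect and higher numbers for a weaker effect at the one concentration tested. Compound 2 stands at the low end of the two numbers; its nearest neighbour is compound 1, and the step between them, a number 7.5 percentage points lower from compound 1 to compound 2 (within the scatter), is within the scatter, so the two are not told apart. Compound 3 `CCCS(=O)(=O)Nc1ccc(F)c(C(=O)c2n[nH]c3ncc(-c4ccc(NS(C)(=O)=O)cc4)cc23)c1F` has not yet been measured. It differs from compound 2 by methanesulfonamido in place of methylsulfonyl on an aromatic carbon. Among the measured compounds shown here, no measured step exchanges this group, so the only guide is that compound 1 and compound 2 carry different groups at the same aromatic carbon and both give low numbers in this assay. On that basis compound 3 is expected to change little, a step of about a number 1.5 percentage points higher from compound 2 to compound 3 (within the scatter), with no movement beyond the scatter expected. The estimate for compound 3 in this assay is 3%, with a range from 0.5% to 15%.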

Compound 3, a percentage reported as activity, at one concentration (the size of the read-out at that concentration, not a potency): 0.85%
Estimate against measurement, compound 3: 2.2 percentage points above; the range from low to high includes it.
By their numbers in this assay, from the lowest: compounds 3, 2 and 1 (each within the scatter of the next).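

In this assay, methanesulfonamido carries a hydrogen-bond donor that methylsulfonyl lacks, yet the exchange gives a step, a number 0.7 percentage points lower from compound 2 to compound 3 (within the scatter), that cannot be told from no change. The wider exchange of 2-hydroxyphenyl for 4-(methanesulfonamido)phenyl gives the same kind of answer, a number 8.2 percentage points lower from compound 1 to compound 3 (within the scatter), so all three groups at this aromatic carbon are compatible with low numbers and are not told apart by this single-concentration read-out. No other measurement bears on this result.

From the compounds shown here alone, whether an amine or a carboxylic acid in place of the sulfonamide on this ring would move the number beyond the scatter remains open. So does whether a longer chain, such as ethyl or propyl, in place of the methyl on the sulfonamide would do so.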